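The source may report more compounds than this note shows. Statements on the series, on what has been measured and on what is new or still open speak of the compounds shown alone.

Values in a functional assay on HL-60 cells (Homo sapiens) for inhibition, read by MTT assay, with a stated time of 72 h; on this read-out lower numbers stand for stronger inhibition and higher numbers for weaker inhibition:
- compound 1 `Cc1nc(-c2ccccc2)c(C(=O)N2CCN(c3cccc(Cl)c3)CC2)o1`: 39.2 nM
- compound 2 `COc1cccc(N2CCN(C(=O)c3oc(C)nc3-c3ccccc3)CC2)c1`: 34.8 nM
- compound 3 `Cc1nc(-c2ccccc2)c(C(=O)N2CCN(c3c(C)cccc3C)CC2)o1`: 146 nM

Compound 3 has the highest number of the three. The gaps to it are a 3.7-fold higher number from compound 1 to compound 3 (0.57 log units; beyond the scatter) and a 4.2-fold higher number from compound 2 to compound 3 (0.62 log units; beyond the scatter). The remaining pair does not separate: a 1.1-fold lower number from compound 1 to compound 2 (0.05 log units; within the scatter).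

The next change leads to compound 4 `Cc1nc(-c2ccccc2)c(C(=O)N2CCN(c3ccccc3F)CC2)o1`, with 2-fluorophenyl in place of 2,6-dimethylphenyl on an amine nitrogen in a ring. Among the compounds with values here, no measured compound carries the 2-fluorophenyl group, so no measured step matches this change directly. The closest evidence is the same two steps to compound 3, read in reverse, since they also replace the 2,6-dimethylphenyl group at this place. Both were modest, and both reversed steps lead to lower numbers. With only two such replacements, and neither of them the 2-fluorophenyl group, the direction is a tentative expectation. A modest move to a lower number is expected in this assay, probably stopping short of the full size of those two steps. The expected step is a 2.4-fold lower number from compound 3 to compound 4 (0.39 log units; beyond the scatter). For compound 4 the estimated value is 60 nM, with an expected range of 25 nM to 150 nM.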

Compound 4, half-maximal inhibitory concentration: 147 nM
Compound 4: the middle estimate sits 2.5-fold (0.39 log units) below what was measured; the measured number falls inside the stated range.
By their numbers in this assay, from the lowest: compounds 2 and 1 (each within the scatter of the next); then compounds 3 and 4 (each within the scatter of the next).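

In this assay the change from 2,6-dimethylphenyl to 2-fluorophenyl on the amine nitrogen in a ring gives a 1.0-fold higher number from compound 3 to compound 4 (0.00 log units; within the scatter) and so does not separate the two groups, although they differ in their substituents and 2-fluorophenyl has one heavy atom fewer. Measured against the other two aryl groups, 2-fluorophenyl gives a 4.2-fold higher number from compound 2 to compound 4 (0.63 log units; beyond the scatter) and a 3.8-fold higher number from compound 1 to compound 4 (0.57 log units; beyond the scatter) so that the four compounds now form two pairs, with 3-chlorophenyl and 3-methoxyphenyl at the lower numbers and 2,6-dimethylphenyl and 2-fluorophenyl at the higher numbers, and no compound shown goes against this split. Nothing available here explains why the four compounds divide in this way.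

From the compounds shown here alone, whether the split follows the place of the substituent on the phenyl ring or the identity of the substituent remains open, since fluorine appears only in the 2-fluorophenyl group and a 3-fluorophenyl group would test this directly. Going by these compounds, the level of the unsubstituted phenyl group at this nitrogen is also open, as is the effect of a carboxylic acid or an amine on that phenyl ring.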